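A few compounds are considered here, and "the series" means these few. Any claim that something is new, unique, unknown or untested is made for them only; others in the source may bear on it.

Measured compounds:
- Compound 1 `CNC(=O)c1cc(Oc2ccc(NC(=O)c3nn(-c4ccccc4C(F)(F)F)c(=O)cc3C)cc2F)ccn1`. In a functional assay on A549 cells (Homo sapiens) for cytotoxicity, read by MTT assay, with a stated time of 72 h (a higher number here means a weaker inhibitor, a lower number a stronger inhibitor), compound 1 gives > 40000 nM, which is a limit of the assay and not a number.
- Compound 2 `Cc1cc(=O)n(-c2ccccc2C(F)(F)F)nc1C(=O)Nc1ccc(Oc2ncnc3ccsc23)c(F)c1`. In this assay compound 2 gives 4680 nM.
- Compound 3 `Cc1cc(=O)n(-c2ccccc2C(F)(F)F)nc1C(=O)Nc1ccc(Oc2ncnc3sccc23)c(F)c1`. In this assay compound 3 gives 16300 nM.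

Compound 3 stands at the higher of the two numbers; the step of a 3.5-fold higher number from compound 2 to compound 3 (0.54 log units; beyond the scatter) separates it from compound 2. Compound 1 sits at the limit of > 40000 nM in this assay, at which 1 of the 3 values shown sits. The two steps from compound 1, an at least 8.5-fold lower number from compound 1 to compound 2 (0.93 log units; beyond the scatter) and an at least 2.4-fold lower number from compound 1 to compound 3 (0.38 log units; beyond the scatter), change only the group on the ether oxygen, as does the step between compound 2 and compound 3.

Compound 4 `Cc1cc(=O)n(-c2ccc(F)c(F)c2)nc1C(=O)Nc1ccc(Oc2ncnc3sccc23)c(F)c1` differs from compound 3 at a different place: 3,4-difluorophenyl in place of 2-(trifluoromethyl)phenyl on an aromatic nitrogen. Among the compounds with values here, none of the measured steps touches the group on the aromatic nitrogen, so no measured step bears on this change, and neither its direction nor its size in this assay can be read from the series so far. The expectation therefore rests on compound 3 alone, whose value in this assay is 16300 nM. Compound 4 is expected at 16000 nM, with a range from 4000 nM to 60000 nM. The estimated step of a 1.0-fold lower number from compound 3 to compound 4 (0.01 log units; within the scatter) is expected to stay within the scatter, with a wide range to cover the lack of any measured precedent.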

Compound 4, half-maximal inhibitory concentration: 15700 nM
Beside the measured number, compound 4's estimate is 1.0-fold (0.01 log units) above it; low and high end bracket the measured number.
By their numbers in this assay, from the lowest: compound 2; then compounds 4 and 3 (each within the scatter of the next). At a limit, above all of these: compound 1.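

In this assay, the first change shown on the aromatic nitrogen, a 1.0-fold lower number from compound 3 to compound 4 (0.02 log units; within the scatter), stays within the scatter, so 3,4-difluorophenyl and 2-(trifluoromethyl)phenyl cannot be told apart at this position on the core of compound 3. The change on the ether oxygen in a 3.5-fold higher number from compound 2 to compound 3 (0.54 log units; beyond the scatter) lies beyond the scatter, whereas this change on the aromatic nitrogen does not, which gives the first contrast between the two places in the series. Nothing measured here bears on why these two groups on the aromatic nitrogen give values within the scatter of each other.

From the compounds shown here alone, this reading rests on a single pair with one group on the ether oxygen, so it stays open whether the same exchange would behave alike with the group on the ether oxygen of compound 2. Also open, going by these compounds, is how this assay responds on the aromatic nitrogen to groups of another kind, such as a methyl, a longer alkyl chain, or a phenyl carrying an amine or a carboxylic acid.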